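Swapping Cyclohexyl for 4-Iodophenyl on the Ether Oxygen

A few compounds are considered here, and "the series" means these few. Any claim that something is new, unique, unknown or untested is made for them only; others in the source may bear on it.

Of the compounds shown here, three sharing one core have been tested in an assay on cells for agonist activity at probable G-protein coupled receptor 34 (Mus musculus), with a stated time of 1 h; on this read-out higher numbers stand for larger maximal responses and lower numbers for smaller maximal responses. Compound 1 `N[C@@H](COP(=O)(O)OCCCOC(=O)CCc1ccccc1OCc1cccc(Cc2ccccc2)c1)C(=O)O` gives 14.5%, compound 2 `N[C@@H](COP(=O)(O)OCCCOC(=O)CCc1ccccc1OCc1cccc(OC2CCCCC2)c1)C(=O)O` gives 18.8%, and compound 3 `Cc1cccc(Oc2cccc(COc3ccccc3CCC(=O)OCCCOP(=O)(O)OC[C@H](N)C(=O)O)c2)c1` gives 21.3%. Compound 2 sits within the scatter of both companions: a number 4.3 percentage points higher from compound 1 to compound 2 (within the scatter), and a number 2.5 percentage points higher from compound 2 to compound 3 (within the scatter). Compound 4 `N[C@@H](COP(=O)(O)OCCCOC(=O)CCc1ccccc1OCc1cccc(Oc2ccc(I)cc2)c1)C(=O)O` has not yet been measured; it differs from compound 2 in one place: 4-iodophenyl in place of cyclohexyl on an oxygen on an aromatic ring. The closest measured step is the comparable move from cyclohexyl to an aromatic ring on the same oxygen, which gave only a small shift, and the wider change a number 6.8 percentage points higher from compound 1 to compound 3 (within the scatter) was likewise small. An expected step of a number 2.2 percentage points higher from compound 2 to compound 4 (within the scatter) therefore stays within the scatter. Compound 4 is estimated at 21%, with a range from 11% to 32%.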

Compound 4, largest response reached (Emax), in percent of the reference or control that the assay uses: 19.1%
For compound 4 the middle estimate is 1.9 percentage points above the measured one; low and high end bracket the measured number.
By their numbers in this assay, from the lowest: compounds 1, 2, 4 and 3 (each within the scatter of the next).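

On this oxygen in this assay, 4-iodophenyl reads the same as the two earlier groups: a number 0.3 percentage points higher from compound 2 to compound 4 (within the scatter), and a number 2.2 percentage points lower from compound 3 to compound 4 (within the scatter). Replacing benzyl on the aromatic carbon with 4-iodophenoxy also gives no readable difference, with a number 4.6 percentage points higher from compound 1 to compound 4 (within the scatter), so adding iodine leaves all four compounds within the scatter of one another. No measurement is available to explain this flat result. The compounds shown leave open whether an amine or a carboxylic acid on this ring would move the response outside that narrow band.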